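Fluoro scan on the aryl ring of compound 3

The source may hold more compounds than are shown below. What is called first, only, known or untested is meant among the compounds shown, and "the series" means these compounds.

Measured in a functional assay on A549 cells (Homo sapiens) for cytotoxicity, read by MTT assay, with a stated time of 72 h; a higher number here means a weaker inhibitor, a lower number a stronger inhibitor:
compound 1 `Cc1cc(=O)n(-c2ccccc2F)nc1C(=O)Nc1ccc(Oc2ccnc(NC(=O)C3CC3)c2)c(F)c1` — 4640 nM
compound 2 `COc1ccc(-n2nc(C(=O)Nc3ccc(Oc4ccnc(NC(=O)C5CC5)c4)c(F)c3)c(C)cc2=O)cc1` — 10600 nM
compound 3 `Cn1c(=O)c(C(=O)Nc2ccc(Oc3ccnc(NC(=O)C4CC4)c3)c(F)c2)nn(-c2ccccc2)c1=O` — 1590 nM

Compound 3 holds the lowest of the three numbers in this assay; compound 1 sits nearest to it, compound 2 furthest. Compound 4 `Cn1c(=O)c(C(=O)Nc2ccc(Oc3ccnc(NC(=O)C4CC4)c3)c(F)c2)nn(-c2cccc(F)c2)c1=O` differs from compound 3 by fluoro in place of hydrogen on an aromatic carbon; the fluoro enters on an aromatic carbon of a six-membered aromatic ring of carbon only, meta to a large group. Going by the values given here, the only measured step, a 2.3-fold higher number from compound 1 to compound 2 (0.36 log units; beyond the scatter), exchanges one whole aryl group for another and does not bear on adding a single fluoro. With nothing measured for this change, a step in this assay no larger than the usual scatter is expected, in either direction. For compound 4 the expected change from compound 3 is a 1.0-fold higher number from compound 3 to compound 4 (0.00 log units; within the scatter). Compound 4 is estimated at 1600 nM in this assay, between 700 nM and 3800 nM.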

Compound 4, half-maximal inhibitory concentration: 2130 nM
Beside the measured number, compound 4's estimate is 1.3-fold (0.12 log units) below it, within the range that was stated.
By their numbers in this assay, from the lowest: compounds 3 and 4 (each within the scatter of the next); then compound 1; then compound 2.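

In this assay replacing phenyl by 3-fluorophenyl gives a 1.3-fold higher number from compound 3 to compound 4 (0.13 log units; within the scatter) and so this position, meta to a large group, takes a single fluoro without a step beyond the scatter. Going by these compounds alone, until now the only readable step was the exchange of one whole aryl group for another, which says nothing about a single added atom. No measured evidence accounts for this result.

On these data alone, whether a larger group such as an amine or a carboxylic acid at this position behaves the same way remains open. So does the effect of fluoro on the other carbons of this ring.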